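Cytotoxicity notes: compound 2 to compound 4

This account rests on a few compounds, and the source may have more. Where it says the series, first, only, none or still open, it means among the compounds named here.

In an ADME assay on BHK-21 cells (Mesocricetus auratus) for cytotoxicity, read by MTT assay, with a stated time of 72 h (on this read-out lower numbers stand for higher toxicity in this test and higher numbers for lower toxicity in this test), the series sits at the low-toxicity end of the scale. Compound 1 `Clc1ccc(NCc2cn(-c3ccccc3)nc2-c2ccc(Cl)cc2)cc1` gives 73000 nM in this assay. Compound 2 `Cc1ccc(NCc2cn(-c3ccccc3)nc2-c2ccc(Cl)cc2)cc1` returns only a limit, > 100000 nM in this assay. Compound 3 `Clc1ccc(NCc2cn(-c3ccccc3)nc2-c2ccc(Br)cc2)cc1` likewise returns a limit, > 100000 nM; > 100000 nM (2 entries) in this assay, in both of its entries. Within the data shown here, the one step measured within the set, an at least 1.3-fold higher number from compound 1 to compound 2 (0.13 log units; that floor lies within the scatter), is a floor that lies within the scatter and so shows no change beyond it. Compound 2 thus stands at the limit, without a number of its own, and the limit of > 100000 nM in this assay, at which 1 of the 3 values shown sits, is where one of the three values shown sits.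

Compound 4 `Cc1ccc(NCc2cn(-c3ccccc3)nc2-c2ccccc2)cc1` differs from compound 2 by hydrogen in place of chloro on an aromatic carbon. Among the measured compounds shown here, no measured step removes a chloro in this way; the only step available, from chloro to methyl, bears on it indirectly and was within the scatter, and both compound 2 and compound 3 sit at the limit. No step beyond the scatter is therefore expected in this assay for compound 4, whose number is expected to remain at or near the limit. Compound 4 is estimated at 100000 nM, with a range from 50000 nM to 200000 nM, so the expected step is a number no higher from compound 2 to compound 4 (the limit leaves the size open).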

Compound 4, half-maximal cytotoxic concentration: > 100000 nM
Compound 4: only a limit was reported (the forecaster's own chance of this, stated with the estimate: 75%); the middle value sits exactly at the limit.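

Compound 2 and compound 4 both return only limits in this assay, so the step between them, hydrogen in place of chloro on an aromatic carbon, cannot be read: the limit of > 100000 nM in this assay, at which 2 of the 4 values shown sit.

The compounds shown leave open whether going from 4-chlorophenyl to phenyl changes the read-out at all, since neither compound 2 nor compound 4 has a number of its own.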